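Working notes on four related compounds in one series

This account rests on a few compounds, and the source may have more. Where it says the series, first, only, none or still open, it means among the compounds named here.

Measured so far in a functional assay on HT-29 cells (Homo sapiens) for cytotoxicity, read by MTT assay, with a stated time of 72 h; on this read-out lower numbers stand for stronger inhibition and higher numbers for weaker inhibition:

compound 1, `COc1cc2c(Oc3ccc(NC(=O)c4cc(-c5ccccc5)ccn4)cc3F)ccnc2cc1OCCCN1CCN(C)CC1`, gives 82 nM
compound 2, `COc1cc2c(Oc3ccc(NC(=O)c4cc(-c5ccccc5C)ccn4)cc3F)ccnc2cc1OCCCN1CCN(C)CC1`, gives 180 nM
compound 3, `COc1cc2c(Oc3ccc(NC(=O)c4cc(-c5ccccc5)ccn4)cc3F)ccnc2cc1OCCCN1CCCCC1`, gives 270 nM

Two single changes are covered. The first is methyl in place of hydrogen on an aromatic carbon, and it produced a 2.2-fold higher number from compound 1 to compound 2 (0.34 log units; beyond the scatter). The second is piperidin-1-yl in place of 4-methylpiperazin-1-yl on a saturated chain carbon, three bonds along the chain from an oxygen on an aromatic ring, and it produced a 3.3-fold higher number from compound 1 to compound 3 (0.52 log units; beyond the scatter). Compound 3 carries the highest number of the three, but its value and that of compound 2 sit within the scatter of one another, so no order between those two is claimed.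

Compound 4, `COc1cc2c(Oc3ccc(NC(=O)c4cc(-c5ccc(C)cc5)ccn4)cc3F)ccnc2cc1OCCCN1CCCCC1`, is not yet measured. It differs from compound 3 by methyl in place of hydrogen on an aromatic carbon, while compound 2 differs from compound 1 by methyl in place of hydrogen on an aromatic carbon; the two cores differ by piperidin-1-yl in place of 4-methylpiperazin-1-yl on a saturated chain carbon, three bonds along the chain from an oxygen on an aromatic ring. The places are not the same: in compound 2 the methyl stands "ortho to a large group", in compound 4 "para to a large group". Among the measured compounds shown here, it is therefore the same kind of change, not the same one, and the only measured step of this kind is a 2.2-fold higher number from compound 1 to compound 2 (0.34 log units; beyond the scatter).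

In this assay a step of a 1.7-fold higher number from compound 3 to compound 4 (0.22 log units; within the scatter) is expected from compound 3 to compound 4, resting on the step of a 2.2-fold higher number from compound 1 to compound 2 (0.34 log units; beyond the scatter) taken as a rough guide, with wide bounds since the place differs. For compound 4 the estimate is 450 nM, expected to fall between 200 nM and 1100 nM.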

Compound 4, half-maximal inhibitory concentration: 340 nM
Compound 4: middle estimate off by 1.3-fold (0.12 log units), on the high side, within the range that was stated.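

In this assay, methyl in place of hydrogen on an aromatic carbon, para to a large group, gives a 1.3-fold higher number from compound 3 to compound 4 (0.10 log units; within the scatter), so no order between these two compounds is claimed. Set beside the earlier step of the same kind, a 2.2-fold higher number from compound 1 to compound 2 (0.34 log units; beyond the scatter), this step is not separated from it by more than the scatter, and the comparison gives no sign that the outcome of adding a methyl depends on the core: the same change on two cores in this assay, a 2.2-fold higher number (0.34 log units; beyond the scatter) from compound 1 to compound 2 and a 1.3-fold higher number (0.10 log units; within the scatter) from compound 3 to compound 4, 1.7-fold (0.24 log units) apart, within the scatter of two such steps. Among the compounds shown here, this does not show that the change carries over unaltered, as only two steps are available and the core and the place of the methyl both differ between them, leaving the contribution of each unreadable.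

The compounds shown leave open what a methyl para to a large group does on the core of compound 1, and what a methyl at the place it occupies in compound 2 does on the core of compound 3, either of which would separate place from core. Also open, as far as these compounds go, is how a methoxy group or a chlorine at the same place would read, and whether a morpholine or dimethylamino group at the end of the chain would follow the same course.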